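The compounds below may be only part of what the source reports. "The series", "measured", "known", "first", "only" and "open" are said of these compounds alone.

Compound 1 `COc1ccc(C(O)c2cn(CCCO)nn2)c(OC)c1OC`: > 100000 nM
Compound 2 `COc1cccc(Cn2cc(-c3ccc4ccccc4c3)nn2)c1`: > 100000 nM

In a functional assay on B16 cells (Mus musculus) for cytotoxicity, read by MTT assay, with a stated time of 48 h (a lower number here means a stronger inhibitor, a higher number a weaker inhibitor), compound 1 gives > 100000 nM, which is a limit of the assay rather than a number. Compound 2 likewise gives > 100000 nM, again a limit. Compound 2 thus stands at the limit of > 100000 nM in this assay, at which 2 of the 2 values shown sit, with no number to compare. Compound 3 `c1ccc(Cn2cc(-c3ccc4ccccc4c3)nn2)cc1` is yet to be measured; it differs from compound 2 by hydrogen in place of methoxy on an aromatic carbon. Nothing measured here shows how this change shifts potency, so no step beyond the scatter is expected in either direction. Compound 3 is therefore estimated near 150000 nM, between 50000 nM and 500000 nM, most likely again reported only as a limit. The step this estimate means, a step that the limit leaves unreadable from compound 2 to compound 3, is expected to stay within the scatter.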

Compound 3, half-maximal inhibitory concentration: 3890 nM
Compound 3: the middle estimate sits 39-fold (1.59 log units) above what was measured, outside the stated range (below it).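

The change from 3-methoxyphenyl to phenyl gives an at least 25-fold lower number from compound 2 to compound 3 (1.41 log units; beyond the scatter) in this assay, so what sits at this position matters in this assay. Compound 3 also shows that the core it shares with compound 2 can give a real number once the methoxy is gone. The full size of the step cannot be read, since compound 2 has only a limit: the limit of > 100000 nM in this assay, at which 2 of the 3 values shown sit.

As far as these compounds go, whether only methoxy lowers activity at this position, or other groups do the same, stays open. A hydroxyl or an amine on the same carbon would begin to answer that.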